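The source may hold more compounds than are shown below. What is called first, only, known or untested is meant among the compounds shown, and "the series" means these compounds.

In a physicochemical assay for lipophilicity, measured as octanol-water partition (a lower number here means a more polar compound, a higher number a more lipophilic compound), compound 2 `Cc1cccc2nc(C#N)c([N+](=O)[O-])n12` gives 1.08, the highest of the three numbers measured. Compound 3 `Cc1cccc2nc(C(N)=O)c([N+](=O)[O-])n12` gives 0.695, and the step of a number 0.39 log units lower from compound 2 to compound 3 (beyond the scatter) lies beyond the scatter. Compound 1 `O=C(O)c1nc2ccccn2c1[N+](=O)[O-]` gives -0.038, the lowest of the three. Compound 4 `N#Cc1nc2ccccn2c1[N+](=O)[O-]` has not yet been measured; it differs from compound 2 by hydrogen in place of methyl on an aromatic carbon. Among the compounds with values here, no measured step involves such a change: the one step available concerns a carbamoyl in place of a cyano on an aromatic carbon and offers no direct guide, so the expectation rests on the change itself. A modest fall in this assay is expected, a number 0.48 log units lower from compound 2 to compound 4 (beyond the scatter). Compound 4 is therefore estimated at 0.6, within a range from 0.3 to 0.9.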

Compound 4, partition coefficient: 0.692
The estimate for compound 4 lay 0.09 log units below the measured number; the range from low to high includes it.
By their numbers in this assay, from the lowest: compound 1; then compounds 4 and 3 (each within the scatter of the next); then compound 2.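

In this assay, the methyl next to the ring nitrogen now has a reading of its own: hydrogen in its place gives a number 0.39 log units lower from compound 2 to compound 4 (beyond the scatter). Compound 4 also links the carboxy compound to the nitriles through one change, with cyano in place of carboxy giving a number 0.73 log units higher from compound 1 to compound 4 (beyond the scatter). Nothing available explains the size of either step.

From the compounds shown here alone, whether an ethyl group or a chlorine at this position would shift the number remains open. So does whether the carboxy to cyano step would hold with the methyl present.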